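Hydroxy for hydrogen on the chain carbon of compound 3

The compounds below may be only part of what the source reports. "The series", "measured", "known", "first", "only" and "open" are said of these compounds alone.

The series shares the core of compound 1 `C=C1C(=O)[C@H]2C[C@]1(O)CC1=C2[C@]2(C)CCC[C@](C)(CO)[C@H]2CC1`, for which a functional assay on HL-60 cells (Homo sapiens) for cytotoxicity, read by MTT assay, with a stated time of 24 h (a lower number here means a stronger inhibitor, a higher number a weaker inhibitor), gives "not determined" (no result reported). Compound 2 `C[C@@H]1C(=O)[C@H]2C[C@]1(O)CC1=C2[C@]2(C)CCC[C@](C)(CO)[C@H]2CC1` reaches only the limit > 50000 nM in this assay. Compound 3 `C[C@@H]1C(=O)[C@H]2C[C@]1(O)CC1=C2[C@]2(C)CCCC(C)(C)[C@H]2CC1` likewise stops at the limit > 50000 nM. The step that the two limits leave unreadable from compound 2 to compound 3 is therefore unreadable, and compound 3 stands nowhere more definite than that limit, as the limit of > 50000 nM in this assay, at which 2 of the 3 values shown sit, records. Compound 4 `C[C@@H]1C(=O)[C@H]2C[C@]1(O)CC1=C2[C@]2(C)CCC[C@@](C)(CO)[C@H]2CC1` differs from compound 3 by hydroxy in place of hydrogen on a saturated chain carbon bound to a saturated ring carbon. Only the unreadable step from compound 2 to compound 3 bears on this change, and it sets no size. No step beyond the scatter is expected in this assay. Compound 4 is estimated at 50000 nM, between 20000 nM and 120000 nM, most likely again a limit. The step of a number no higher from compound 3 to compound 4 (the limit leaves the size open) is the expected outcome.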

Compound 4, half-maximal inhibitory concentration: > 50000 nM
Compound 4: no number, only a limit (the forecaster's own chance of this, stated with the estimate: 80%); the middle value lies on the limit itself.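

Among these compounds, compound 2, compound 3 and compound 4 all stop at a limit, and no step among them can be read. Going by these compounds, whether hydroxy in place of hydrogen on a saturated chain carbon, or the configuration as drawn, changes the result in this assay stays open.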